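A few compounds are considered here, and "the series" means these few. Any claim that something is new, unique, unknown or untested is made for them only; others in the source may bear on it.

Measured compounds and their values:
Compound 1, `CNC(=O)Nc1ccccc1-c1ccc(CN2C(=O)[C@H](NC(=O)CC(C)(C)N)CCc3ccccc32)cc1` — in a functional assay (Pituitary gland cell) with Rattus norvegicus as the target (on this read-out lower numbers stand for an effect already at smaller amounts and higher numbers for an effect only at larger amounts of compound), compound 1 gives 50 nM.
Compound 2, `CC(C)(N)C(=O)N[C@@H]1CCc2ccccc2N(Cc2ccc(-c3ccccc3CNC(=O)NCCO)cc2)C1=O` — in this assay compound 2 gives 2 nM.
Compound 3, `CCCNC(=O)NCc1ccccc1-c1ccc(CN2C(=O)[C@H](NC(=O)C(C)(C)N)CCc3ccccc32)cc1` — in this assay compound 3 gives 144 nM.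

Compound 1 stands second highest of the three numbers; its nearest neighbour is compound 3, a higher number, and its furthest is compound 2, a far lower one.

The unmeasured compound 4, `CC(C)(N)CC(=O)N[C@@H]1CCc2ccccc2N(Cc2ccc(-c3ccccc3CN)cc2)C1=O`, differs from compound 1 in one place: aminomethyl in place of (methylcarbamoyl)amino on an aromatic carbon.

Only one step between measured compounds is shown, a 72-fold higher number from compound 2 to compound 3 (1.86 log units; beyond the scatter), and it concerns a different place, a methyl in place of a hydroxy on a saturated chain carbon, two bonds along the chain from an amide-type nitrogen. No step shown touches the (methylcarbamoyl)amino group or its replacement, so the expectation for compound 4 rests on no directly comparable measurement. The group that leaves carries a second hydrogen-bond donor and a double bond outside aromatic rings; the aminomethyl that enters is smaller. The modest step toward a higher number that is expected here is a 2.4-fold higher number from compound 1 to compound 4 (0.38 log units; beyond the scatter), and this expectation carries wide uncertainty.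

Compound 4 is therefore estimated at 120 nM in this assay, with a range from 20 nM to 700 nM.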

Compound 4, concentration for half-maximal effect: > 1000 nM
Compound 4 gave a limit, no number; the forecaster's own chance of this, stated with the estimate: 5%; middle value at least 8.3-fold (0.92 log units) from the limit.
By their numbers in this assay, from the lowest: compound 2; then compound 1; then compound 3. At a limit, above all of these: compound 4.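

Until compound 4, no step shown touched this aromatic carbon, ortho to a large group, and putting aminomethyl in place of (methylcarbamoyl)amino there now gives an at least 20-fold higher number from compound 1 to compound 4 (1.30 log units; beyond the scatter) in this assay as a large change. Compound 4 reads > 1000 nM in this assay, and that value is a limit of the assay, not a number. The pair thus shows that the read-out is far from indifferent to which of these two groups sits on this carbon, while the full size of the step stays unknown, its only bound being this limit: the limit of > 1000 nM in this assay, at which 1 of the 4 values shown sits.

The compounds shown leave open whether a plain amino group, an acetylamino group or a carboxylic acid on this aromatic carbon would read close to compound 1 or would go the way of compound 4. Within the data shown here, they also leave open whether the same exchange would give a step of similar size in a compound with a different side chain on the shared core, such as compound 2 or compound 3, since this one pair is the only reading of the change.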